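Swapping the Piperidine Side Chain at Ghrelin Receptor Binding

The compounds below may be only part of what the source reports. "The series", "measured", "known", "first", "only" and "open" are said of these compounds alone.

Measured so far:
compound 1, `CCO[C@@H](C)CN1CCC[C@H](Cn2c(-c3cccnc3C)nc3cn(-c4cccc(OC)c4)nc3c2=O)C1`: 5 nM
compound 2, `CCO[C@H](C)CN1CCC[C@H](Cn2c(-c3cccnc3C)nc3cn(-c4cccc(OC)c4)nc3c2=O)C1`: 40 nM

Among the measured compounds shown here, in an assay on HEK293 cells for displacement of a labelled ligand from growth hormone secretagogue receptor type 1 (Homo sapiens), with a stated time of 60 min (on this read-out lower numbers stand for stronger inhibition and higher numbers for weaker inhibition), compound 2 stands at the higher of the two numbers, the only neighbour being compound 1, with the step of an 8.0-fold higher number from compound 1 to compound 2 (0.90 log units; beyond the scatter) resting on (the fact that compounds 1 and 2 differ only in the configuration as drawn). Compound 3, `COC[C@H](C)N1CCC[C@H](Cn2c(-c3cccnc3C)nc3cn(-c4cccc(OC)c4)nc3c2=O)C1`, differs from compound 2 by 1-(methoxymethyl)ethyl in place of 2-ethoxypropyl on an amine nitrogen in a ring. For the measured compounds named here, the single measured step concerns configuration only, not the side chain itself, so it gives no direct guide to this change. Compound 3 is therefore expected to land near compound 2, with a 1.3-fold lower number from compound 2 to compound 3 (0.12 log units; within the scatter) taken as no step beyond the scatter and wide uncertainty. The estimate for compound 3 in this assay is 30 nM, ranging from 6 nM to 150 nM.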

Compound 3, half-maximal inhibitory concentration: 1.7 nM
Beside the measured number, compound 3's estimate is 18-fold (1.25 log units) above it, outside the stated range (below it).
By their numbers in this assay, from the lowest: compound 3; then compound 1; then compound 2.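

In this assay, 1-(methoxymethyl)ethyl in place of 2-ethoxypropyl on the amine nitrogen in the ring gives a 24-fold lower number from compound 2 to compound 3 (1.37 log units; beyond the scatter) and also a 2.9-fold lower number from compound 1 to compound 3 (0.47 log units; beyond the scatter) in the same direction. This position therefore responds to the side chain itself, whichever drawn configuration the 2-ethoxypropyl group has, and not only to configuration as the earlier pair showed. What lies behind these steps cannot be told from the data given.

On these data alone, the effect of inverting the stereocentre of 1-(methoxymethyl)ethyl remains open. So does how a side chain ending in a carboxylic acid or an amine would fare on this nitrogen.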